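Adding One Methyl to Compound 2

The source may hold more compounds than are shown below. What is called first, only, known or untested is meant among the compounds shown, and "the series" means these compounds.

A compound's toxicity to cells is worth knowing early, and a single small change can sometimes alter it. In an ADME assay on BALB/3T3 cells (Mus musculus) for cytotoxicity, read by sulforhodamine B assay, with a stated time of 72 h (a higher number here means a weaker inhibitor, a lower number a stronger inhibitor), compound 1 (`CC(=O)N[C@@H](CSC(=S)NCCCNC(=S)SC[C@H](NC(C)=O)C(=O)O)C(=O)O`) gives 8650 nM. Compound 2 (`CC(=O)N[C@@H](CSC(=S)Nc1cccc(NC(=S)SC[C@H](NC(C)=O)C(=O)O)c1)C(=O)O`) gives > 100000 nM in this assay, which is a limit of the assay and not a number. Its true value is therefore unknown.

Compound 3 (`CC(=O)N[C@@H](CSC(=S)Nc1ccc(C)c(NC(=S)SC[C@H](NC(C)=O)C(=O)O)c1)C(=O)O`) carries methyl in place of hydrogen on an aromatic carbon. This new methyl is ortho to a large group and para to a large group. Among the compounds with values here, no measured pair shows what such a change does in this assay, so the size of the step is a judgement. A small step is expected, perhaps a modest move toward stronger inhibition, and the reading may well stay at the limit. This expectation rests on compound 2, for which the data give (the limit of > 100000 nM in this assay, at which 1 of the 2 values shown sits). The estimated change is an at least 1.2-fold lower number from compound 2 to compound 3 (0.09 log units; that floor lies within the scatter). For compound 3, the expected value is 80000 nM, with an estimated range from 20000 nM to 200000 nM.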

Compound 3, half-maximal inhibitory concentration: 54700 nM
Compound 3: middle estimate off by 1.5-fold (0.17 log units), on the high side; the measured number falls inside the stated range.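

In this assay, methyl in place of hydrogen on an aromatic carbon, ortho to a large group and para to a large group, gives an at least 1.8-fold lower number from compound 2 to compound 3 (0.26 log units; that floor lies within the scatter), so this single change is compatible with a real shift, but the printed floor alone does not establish one. Unlike the reading for compound 2, the reading for compound 3 is a number, 54700 nM, which gives this aromatic pair a measured point that later changes at this position could be set against. The step can only be stated as a floor, because the reading for compound 2 is a limit of the assay and not a number: the limit of > 100000 nM in this assay, at which 1 of the 3 values shown sits.

On these data alone, it remains open whether ethyl, a chlorine atom or a hydroxyl group on the same aromatic carbon would give a similar reading, and whether methyl on another carbon of that ring would act in the same way. As far as these compounds go, the true size of this step also remains unknown, and a single pair cannot show whether the same change would do the same on a different core.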